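Amine for methoxy on a benzoxazole-free core: compound 4 expected

The compounds below may be only part of what the source reports. "The series", "measured", "known", "first", "only" and "open" are said of these compounds alone.

Measured compounds:
compound 1 `COc1ccc(-c2nc3cccc(-c4cc(OC)c(OC)c(OC)c4)c3o2)cc1` — > 25000 nM
compound 2 `COc1cc(-c2cccc3nc(-c4cccc(Br)c4)oc23)cc(OC)c1OC` — 6800 nM
compound 3 `COc1cc(-c2nc3cccc(-c4cc(OC)c(OC)c(OC)c4)c3o2)ccc1O` — 10300 nM

Compound 1 is the only one of the three for which a functional assay on U-251 cells (Homo sapiens) for antiproliferative activity, read by MTT assay, with a stated time of 48 h (a higher number here means a weaker inhibitor, a lower number a stronger inhibitor), gives no number but a limit (the limit of > 25000 nM in this assay, at which 1 of the 3 values shown sits); its value of > 25000 nM is that limit, so compound 1 stands at the weak end of the numbers shown. Compound 2 gives 6800 nM in this assay, and compound 3 gives 10300 nM. Both steps away from compound 1 lowered the number: an at least 3.6-fold lower number from compound 1 to compound 2 (0.56 log units; beyond the scatter) and an at least 2.4-fold lower number from compound 1 to compound 3 (0.38 log units; beyond the scatter). Between compound 2 and compound 3 the difference is a 1.5-fold higher number from compound 2 to compound 3 (0.18 log units; within the scatter).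

Compound 4 `COc1cc(-c2cccc3nc(-c4ccc(N)cc4)oc23)cc(OC)c1OC` has not yet been measured in this assay. It differs from compound 1 by amino in place of methoxy on an aromatic carbon. The two measured steps from compound 1 both replace the 4-methoxyphenyl group, each with at least a modest lowering of the number; the change to amino in place of methoxy on an aromatic carbon is smaller than either of those replacements, so a step of similar or somewhat smaller size, in the same downward direction, is expected for compound 4, as an at least 2.7-fold lower number from compound 1 to compound 4 (0.44 log units; beyond the scatter). Compound 4 is therefore estimated to give 9000 nM in this assay, with a range from 3000 nM to 30000 nM.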

Compound 4, half-maximal inhibitory concentration: 1040 nM
For compound 4 the middle estimate is 8.7-fold (0.94 log units) above the measured one; measured number below the stated range.
By their numbers in this assay, from the lowest: compound 4; then compounds 2 and 3 (each within the scatter of the next). At a limit, above all of these: compound 1.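

In this assay, amino in place of methoxy on this aromatic carbon, para to a large group, gives an at least 24-fold lower number from compound 1 to compound 4 (1.38 log units; beyond the scatter), so a change confined to this one substituent can move the number far more than the group's small difference in heavy atoms might suggest. Among these compounds, the earlier compounds showed only that replacing the 4-methoxyphenyl group lowered the number, with compound 2 and compound 3 within the scatter of each other, whereas the 4-aminophenyl group now separates clearly from both, with a 9.9-fold lower number from compound 3 to compound 4 (1.00 log units; beyond the scatter) and a 6.5-fold lower number from compound 2 to compound 4 (0.82 log units; beyond the scatter). Compound 1 stands at a limit, so the step from it is a bound and not a full size: the limit of > 25000 nM in this assay, at which 1 of the 4 values shown sits.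

The compounds shown leave open whether the lower number belongs to the amino group itself or would persist with a methylamino, a dimethylamino or an acetamido group on the same carbon. They also leave open how a hydroxy group alone on that carbon would compare, as compound 3 carries one only together with a methoxy group.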